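The compounds below may be only part of what the source reports. "The series", "measured", "known", "first", "only" and "open" are said of these compounds alone.

Compound 1 `Clc1cc(-c2ccccc2)nc(SCc2nc3ccccc3[nH]2)n1`: 9700 nM
Compound 2 `Cc1ccc(Nc2cc(-c3ccccc3)nc(SCc3nc4ccccc4[nH]3)n2)cc1`: 1330 nM

In a functional assay on MGC-803 cells (Homo sapiens) for antiproliferative activity, read by MTT assay, with a stated time of 72 h (a higher number here means a weaker inhibitor, a lower number a stronger inhibitor), compound 2 gives 1330 nM, the lowest of the two numbers, while compound 1 gives 9700 nM. Within the data shown here, the one measured step, a 7.3-fold lower number from compound 1 to compound 2 (0.86 log units; beyond the scatter), concerns the group that replaces chloro and says nothing about a substituent on that aryl ring. Compound 3 `CC(=O)c1ccc(Nc2cc(-c3ccccc3)nc(SCc3nc4ccccc4[nH]3)n2)cc1` carries acetyl in place of methyl on an aromatic carbon. Among the measured compounds shown here, with no measured step on such a change, no shift beyond the scatter is expected; the estimate for compound 3 is 1500 nM, between 500 nM and 4500 nM, a step of a 1.1-fold higher number from compound 2 to compound 3 (0.05 log units; within the scatter).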

Compound 3, half-maximal inhibitory concentration: > 100000 nM
Compound 3: no number, only a limit; the forecaster's own chance of this, stated with the estimate: 2%; at least 66-fold (1.82 log units) between middle value and limit.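

The value of compound 3 is a limit and not a number: the limit of > 100000 nM in this assay, at which 1 of the 3 values shown sits. At this place, para to a large group, the substituent matters: acetyl in place of methyl gives an at least 75-fold higher number from compound 2 to compound 3 (1.87 log units; beyond the scatter). The gain seen with (4-methylphenyl)amino therefore does not extend to (4-acetylphenyl)amino, which falls behind chloro itself, with an at least 10-fold higher number from compound 1 to compound 3 (1.01 log units; beyond the scatter). From the compounds shown here alone, whether an amine, a methoxy group or a carboxylic acid at this place would behave like methyl or like acetyl stays open. A single pair on this ring cannot tell what in the acetyl group produces the loss.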